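The source may hold more compounds than are shown below. What is called first, only, known or untested is meant among the compounds shown, and "the series" means these compounds.

Measured so far in an ADME assay on microsomes from liver (Rattus norvegicus) for metabolic stability, read by LC-MS, tested at 1 uM; on this read-out higher numbers stand for a longer-lived compound and lower numbers for a shorter-lived compound:
- Compound 1 `Nc1ncnc2c1c(Nc1cccc(Cl)c1)nn2CC1CCNCC1` gives 0.333 h
- Compound 2 `CN1CCC(Cn2nc(Oc3cccc(Cl)c3)c3c(N)ncnc32)CC1` gives > 1 h

Compound 2 gives > 1 h as a limit of the assay and not as a number. Compound 3 `Nc1ncnc2c1c(Oc1cccc(Cl)c1)nn2CC1(C(F)(F)F)CC1` differs from it in one group: 1-(trifluoromethyl)cyclopropyl in place of 1-methylpiperidin-4-yl on a saturated chain carbon bound to an aromatic nitrogen with 1-(trifluoromethyl)cyclopropyl in place of 1-methylpiperidin-4-yl on a saturated chain carbon bound to an aromatic nitrogen. Within the data shown here, no measured pair shows this change, so the expectation rests on little. The estimated step that the limit leaves unreadable from compound 2 to compound 3 is expected to stay within the usual scatter of this assay in either direction. For compound 3 the estimated half-life is 1.2 h with an expected range from 0.5 h to 3 h in this assay.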

Compound 3, half-life: 0.183 h
Compound 3: middle estimate off by 6.6-fold (0.82 log units), on the high side, and the stated range ends above it.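

Putting 1-(trifluoromethyl)cyclopropyl in place of 1-methylpiperidin-4-yl on a saturated chain carbon bound to an aromatic nitrogen gives an at least 5.4-fold lower number from compound 2 to compound 3 (0.73 log units; beyond the scatter) in this assay. This position therefore affects the half-life, and these two groups are not interchangeable here. The true step may be larger, since compound 2 stands at a limit of the assay and not at a number: the limit of > 1 h in this assay, at which 1 of the 3 values shown sits.

Which part of the change carries the step stays open, since ring size, the ring nitrogen and the fluorines all change at once. A cyclohexyl group or an unsubstituted cyclopropyl group at this place would help separate them.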